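Isopropyl for Trifluoromethoxy: Does Inhibition Move?

The source may hold more compounds than are shown below. What is called first, only, known or untested is meant among the compounds shown, and "the series" means these compounds.

Of the compounds shown here, two of one shared core have been measured in an assay on CHO cells for displacement of a labelled ligand from adenosine receptor A3 (Homo sapiens), read by scintillation counting, tested at 10 uM; a lower number here means less inhibition, a higher number more inhibition at the concentration tested (going by the name of the read-out). Compound 1, `CC(C)(C)Cc1c(-c2ccc(F)cc2F)sc(N)c1C(=O)c1ccc(Cl)cc1`, gives 1% in this assay. Compound 2, `CC(C)(C)Cc1c(-c2ccc(OC(F)(F)F)cc2)sc(N)c1C(=O)c1ccc(Cl)cc1`, gives 1% in this assay, level with compound 1 at the digits printed; the gap between the two lies within the scatter. Compound 3, `CC(C)c1ccc(-c2sc(N)c(C(=O)c3ccc(Cl)cc3)c2CC(C)(C)C)cc1`, has not yet been measured. It differs from compound 2 in one place: isopropyl in place of trifluoromethoxy on an aromatic carbon. Going by the values given here, no step between measured compounds is on record, so the two values shown are the only guide, and both sit near the bottom of the scale. The step from compound 2 to compound 3 is expected to be small, a number 2 percentage points higher from compound 2 to compound 3 (within the scatter), with no direction beyond the scatter. Compound 3 is therefore estimated at 3% in this assay, with a range from 0% to 15%.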

Compound 3, a percentage reported as inhibition, at one concentration (the size of the read-out at that concentration, not a potency): 1%
Compound 3: the middle estimate sits 2 percentage points above what was measured; the range from low to high includes it.
By their numbers in this assay, from the lowest: compounds 1, 2 and 3 (each within the scatter of the next).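

In this assay, going by these compounds alone, isopropyl in place of trifluoromethoxy on an aromatic carbon, para to a large group, gives no change at the digits printed from compound 2 to compound 3 (within the scatter) and is the first step on record at this position. The swap removes the oxygen, the fluorines and the hydrogen-bond acceptor from this place, and the read-out stays put, while 4-isopropylphenyl in place of 2,4-difluorophenyl likewise gives no change at the digits printed from compound 1 to compound 3 (within the scatter) in the same assay. No measured property of these groups bears on this result.

All three compounds sit near the bottom of the scale, so the compounds shown do not tell whether this position can influence inhibition at all. Going by these compounds, whether an amine, a carboxylic acid or a longer chain at this place would lift the read-out remains open.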